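A few compounds are considered here, and "the series" means these few. Any claim that something is new, unique, unknown or untested is made for them only; others in the source may bear on it.

Series notes, measured in a functional assay on Jurkat cells (Homo sapiens) for inhibition, read by MTT assay, with a stated time of 72 h; a higher number here means a weaker inhibitor, a lower number a stronger inhibitor:

- compound 1 `CO[C@@H](c1ccccc1)[C@H]1O[C@@H]2CC(=O)O[C@@H]2[C@H]1O`: 12600 nM
- compound 2 `CO[C@@H]1[C@H]2OC(=O)C[C@H]2O[C@@H]1C(O)(c1ccccc1)c1ccccc1`: 9790 nM
- compound 3 `CO[C@H](c1ccccc1)[C@H]1O[C@@H]2CC(=O)O[C@@H]2[C@H]1O`: 15600 nM

Compound 3, at 15600 nM, lies within the scatter of both compound 1 and compound 2, so the three values give no ranking.

The next compound is compound 4 `CO[C@@H]1[C@H]2OC(=O)C[C@H]2O[C@@H]1[C@H](OC)c1ccccc1`, still unmeasured in this assay. It differs from compound 3 by methyl in place of hydrogen on an oxygen on a saturated carbon, that is, hydroxy to methoxy.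

Going by the values given here, the only measured step, a 1.2-fold higher number from compound 1 to compound 3 (0.09 log units; within the scatter), stays within the scatter. It offers limited guidance here, given (the fact that compounds 1 and 3 differ only in the configuration as drawn). Among the compounds with values here, no measured step isolates hydroxy to methoxy, so the size of this change has no direct precedent. The expectation therefore rests on the close grouping of compound 1 at 12600 nM, compound 2 at 9790 nM and compound 3 at 15600 nM. No shift beyond the scatter is expected, although the uncertainty is wide because the evidence is so thin.

The expected step is a 1.4-fold lower number from compound 3 to compound 4 (0.15 log units; within the scatter).

The estimated value for compound 4 is 11000 nM, with an expected range of 4000 nM to 30000 nM.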

Compound 4, half-maximal inhibitory concentration: 2360 nM
Beside the measured number, compound 4's estimate is 4.7-fold (0.67 log units) above it; the measured number lies below the stated range.
By their numbers in this assay, from the lowest: compound 4; then compounds 2, 1 and 3 (each within the scatter of the next).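

In this assay, going by these compounds alone, hydroxy to methoxy gives the only step that lies beyond the scatter, a 6.6-fold lower number from compound 3 to compound 4 (0.82 log units; beyond the scatter), so a single methyl on this oxygen on a saturated carbon is enough to move the number clearly. The hydrogen on this oxygen is therefore not needed for activity in this assay, and replacing it with methyl gives the stronger inhibitor of this pair. The earlier step, a 1.2-fold higher number from compound 1 to compound 3 (0.09 log units; within the scatter), stayed within the scatter and could say nothing about this oxygen: the fact that compounds 1 and 3 differ only in the configuration as drawn

The compounds shown carry no ethoxy, benzyloxy or acetyl group on this oxygen, so it remains open whether the gain continues with a larger group or is particular to methyl. Within the data shown here, it also remains open whether the same change gives a step of similar size on compound 1, which has the other drawn configuration at the chain carbon, and the single pair gives no measured basis for explaining the step.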